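The source may hold more compounds than are shown below. What is called first, only, known or untested is meant among the compounds shown, and "the series" means these compounds.

Measured so far:
- compound 1 `COc1ccc(-c2ccc(-c3ccc(-c4nc5cc(C)ccc5[nH]4)cc3)cc2)cc1OC`: 2100 nM
- compound 2 `Oc1cccc2[nH]c(-c3ccc(-c4ccc(-c5ccc(C(F)(F)F)cc5)cc4)cc3)nc12`: 3610 nM
- compound 3 `CN(C)c1ccc(-c2ccc(-c3ccc(-c4nc5c(O)cccc5[nH]4)cc3)cc2)cc1`: 7100 nM

In a functional assay on A549 cells (Homo sapiens) for inhibition, read by sulforhodamine B assay (on this read-out lower numbers stand for stronger inhibition of growth and higher numbers for weaker inhibition of growth), compound 3 gives 7100 nM. This lies within the scatter of compound 2 and is a higher number, beyond the scatter, than compound 1.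

Compound 4 `COc1ccc(-c2ccc(-c3ccc(-c4nc5c(O)cccc5[nH]4)cc3)cc2)cc1OC` keeps the core of compound 3 and swaps one end group: 3,4-dimethoxyphenyl in place of 4-(dimethylamino)phenyl on an aromatic carbon. Among the measured compounds shown here, the only measured step that bears directly on this swap is a 2.0-fold higher number from compound 2 to compound 3 (0.29 log units; within the scatter), which stays within the scatter. Compound 1 already carries 3,4-dimethoxyphenyl on a different core and gives 2100 nM, which hints at a lower number. The estimated change is therefore modest: a 1.6-fold lower number from compound 3 to compound 4 (0.20 log units; within the scatter). For compound 4 the expected value is 4500 nM, with an estimated range of 2000 nM to 9500 nM.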

Compound 4, concentration for 50% growth inhibition: 1310 nM
Estimate against measurement, compound 4: 3.4-fold (0.54 log units) above; measured number outside the range, below it.
By their numbers in this assay, from the lowest: compounds 4, 1, 2 and 3 (each within the scatter of the next, the first and the last beyond it).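

In this assay, the end group on this core matters more than the earlier swap suggested: 3,4-dimethoxyphenyl clearly beats both 4-(dimethylamino)phenyl (a 5.4-fold lower number from compound 3 to compound 4 (0.73 log units; beyond the scatter)) and 4-(trifluoromethyl)phenyl (a 2.8-fold lower number from compound 2 to compound 4 (0.44 log units; beyond the scatter)). With that end group in place, changing the other end of the molecule to 4-hydroxy-1H-benzimidazol-2-yl makes no real difference (a 1.6-fold lower number from compound 1 to compound 4 (0.20 log units; within the scatter)). No measurement here explains why this end group does better.

Still open, on these data alone, is whether both methoxy groups are needed, and how an end ring carrying a carboxylic acid or a morpholine would compare.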